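The source may report more compounds than this note shows. Statements on the series, on what has been measured and on what is new or still open speak of the compounds shown alone.

For the measured compounds named here, compound 2 `C[C@H](NC(=O)C(c1cnccn1)N(C(=O)c1c[nH]cn1)c1ccc(-c2ccccc2)cc1)c1ccccc1` is the only one of the pair with an actual number in a toxicity assay on Vero C1008 cells (Chlorocebus sabaeus) for cytotoxicity, read by neutral red uptake, with a stated time of 5 days; on this read-out higher numbers stand for lower toxicity in this test and lower numbers for higher toxicity in this test: in this assay compound 2 gives 148000 nM. Compound 1 `C[C@H](NC(=O)C(c1cccnc1)N(C(=O)c1ccco1)c1ccc(-c2ccccc2)cc1)c1ccccc1` reaches only the edge of the test, and in this assay compound 1 gives > 200000 nM, which is a limit of the assay rather than a number (the limit of > 200000 nM in this assay, at which 1 of the 2 values shown sits). Going by the values given here, since no two measured compounds differ in a single place, no measured step can be described. Compound 3 `C[C@H](NC(=O)C(c1cnccn1)N(C(=O)c1ccco1)c1ccc(-c2ccccc2)cc1)c1ccccc1` has not yet been measured. It differs from compound 2 in one place: furan-2-yl in place of 1H-imidazol-4-yl on a carbonyl carbon. Compound 1 carries the same furan-2-yl group as compound 3, though it differs elsewhere. Compound 3 is expected to sit somewhat higher, an estimated step of a 1.4-fold higher number from compound 2 to compound 3 (0.13 log units; within the scatter), a modest move that may not clear the usual scatter. In this assay compound 3 is expected to give 200000 nM, ranging from 100000 nM to 400000 nM, and it may well return as a limit.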

Compound 3, half-maximal cytotoxic concentration: > 200000 nM
Compound 3 ended at the assay's limit; the forecaster's own chance of this, stated with the estimate: 55%; the middle value sits exactly at the limit.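

With the shared core held fixed, replacing 1H-imidazol-4-yl with furan-2-yl on a carbonyl carbon whose other neighbour is the amide-type nitrogen gives, in this assay, an at least 1.3-fold higher number from compound 2 to compound 3 (0.13 log units; that floor lies within the scatter), so this position now has a measured step, though its readable floor does not clear the usual scatter. Compound 3 gives a limit of the assay rather than a number, and it stands there with compound 1: the limit of > 200000 nM in this assay, at which 2 of the 3 values shown sit. The other step, pyrazin-2-yl in place of pyridin-3-yl on the saturated chain carbon, cannot be read, as both of its ends are limits.

The compounds shown leave open how far past the limit compound 3 would lie, so the true size of the step remains unknown. They also leave open whether a thiophen-2-yl or a methyl group on the same carbonyl carbon would return a number in this assay.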